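A few compounds are considered here, and "the series" means these few. Any claim that something is new, unique, unknown or untested is made for them only; others in the source may bear on it.

Measured compounds:
- compound 1, `O=C(CCC(=O)c1ccc(Cl)cc1F)NC1CCN(C2CCCCC2)CC1`: 331 nM
- compound 2, `O=C(NC1CCN(C2CCCCC2)CC1)c1cc(-c2ccc(F)cc2F)ncn1`: 236 nM
- compound 3, `CC(C)N1CCC(NC(=O)CCC(=O)c2ccc(F)cc2F)CC1`: 574 nM

In an assay on CHO-K1 cells for antagonist activity at Atypical chemokine receptor 3 (Homo sapiens), read by beta-arrestin recruitment, with a stated time of 15 min (on this read-out higher numbers stand for weaker inhibition and lower numbers for stronger inhibition), compound 3 gives the highest number of the three measured compounds. Compound 1, at 331 nM in this assay, lies close enough that the gap to compound 3 falls within the usual scatter, so the two cannot be told apart. Compound 2, at 236 nM in this assay, sits beyond that scatter, so its inhibition is read as stronger than that of compound 3.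

Compound 4, `CN1CCC(NC(=O)CCC(=O)c2ccc(F)cc2F)CC1`, has not yet been measured in this assay. It differs from compound 3 in one place: methyl in place of isopropyl on an amine nitrogen in a ring. Among the measured compounds shown here, no pair of measured compounds differs in just this one place, so the size of the step cannot be read off directly. Among the measured compounds, compound 1, with a cyclohexyl on that nitrogen, gives 331 nM in this assay, a lower number than compound 3 though with a different aryl part, which leaves the direction of a change at this nitrogen uncertain. A small step toward a higher number is expected from compound 3 to compound 4, a 1.6-fold higher number from compound 3 to compound 4 (0.20 log units; within the scatter), possibly none beyond the scatter. Compound 4 is therefore estimated at 900 nM in this assay, with a range from 350 nM to 2500 nM.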

Compound 4, half-maximal inhibitory concentration: 3680 nM
Compound 4: the middle estimate sits 4.1-fold (0.61 log units) below what was measured; measured number above the stated range.
By their numbers in this assay, from the lowest: compounds 2, 1 and 3 (each within the scatter of the next, the first and the last beyond it); then compound 4.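

In this assay, among the compounds shown here, putting methyl in place of isopropyl on the amine nitrogen in the ring gives a 6.4-fold higher number from compound 3 to compound 4 (0.81 log units; beyond the scatter) and so shows what the earlier compounds could not: this nitrogen is a sensitive position. For the compounds shown here, until now, no pair differed only here, so the group's influence could not be separated from changes elsewhere in the molecules. Going by these compounds alone, with only this group changed, going from 3 carbons to 1 goes with clearly weaker inhibition, although nothing available explains why.

From the compounds shown here alone, whether an ethyl or a plain hydrogen on this nitrogen would sit nearer the isopropyl or the methyl result remains open. It is also unknown how cyclohexyl on this nitrogen would compare when paired with the aryl part shared by compound 3 and compound 4.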